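A few compounds are considered here, and "the series" means these few. Any claim that something is new, unique, unknown or untested is made for them only; others in the source may bear on it.

Measured so far in a functional assay on Sf9 cells for antagonist activity at histamine H2 receptor (Homo sapiens), with stated times of 2 min and 20 min; on this read-out higher numbers stand for higher potency (the scale is a negative logarithm) and lower numbers for lower potency:
compound 1 `CC(CC(=O)/N=C(\N)NCCCc1ccccc1)c1ccccc1` gives 5.89.
compound 2 `N/C(=N\C(=O)CC(c1ccccc1)c1ccccc1)NCCCc1ccccc1` gives 5.89.
compound 3 `N/C(=N\C(=O)CC(c1ccccc1)c1ccccc1)NCCCc1ccccn1` gives 5.68.

Compound 3 holds the lowest of the three numbers in this assay, yet its gaps to compound 1 and to compound 2 both lie within the scatter, so no order among the three can be claimed.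

Compound 4 `N/C(=N\C(=O)CC(c1ccccc1)c1ccccc1)NCCCc1ccncc1` is not yet measured. It differs from compound 3 by pyridin-4-yl in place of pyridin-2-yl on a saturated chain carbon, three bonds along the chain from an amine nitrogen.

Two steps are known: no change at the digits printed from compound 1 to compound 2 (within the scatter) and a number 0.21 log units lower from compound 2 to compound 3 (within the scatter). Neither moves the ring nitrogen within a pyridine, so neither bears directly on the change at hand; the second touches the same place and stayed within the scatter. The step from compound 3 to compound 4 in this assay is therefore expected to be a number 0.02 log units higher from compound 3 to compound 4 (within the scatter), none beyond the scatter. Compound 4 is estimated at 5.7, range 5.2 to 6.2.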

Compound 4, negative logarithm of the antagonist equilibrium constant: 6.14
For compound 4 the middle estimate is 0.44 log units below the measured one; the range from low to high includes it.
By their numbers in this assay, from the lowest: compounds 3, 1, 2 and 4 (each within the scatter of the next, the first and the last beyond it).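

In this assay, among these compounds, the place of the ring nitrogen within the pyridine now counts at this position, on a saturated chain carbon three bonds along the chain from an amine nitrogen: pyridin-4-yl in place of pyridin-2-yl gives a number 0.46 log units higher from compound 3 to compound 4 (beyond the scatter), the only step so far beyond the scatter. Pyridin-4-yl in place of phenyl gives a number 0.25 log units higher from compound 2 to compound 4 (within the scatter), so this change separates the two pyridines but not compound 4 from compound 2. No measurement shown accounts for the gap between the two pyridines. Open, as far as these compounds go, is where pyridin-3-yl would fall relative to these two isomers. Also open, from the compounds shown here alone, is how a longer chain than 3-(pyridin-4-yl)propyl would read.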